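The source may report more compounds than this note shows. Statements on the series, on what has been measured and on what is new or still open speak of the compounds shown alone.

Compound 1 `CCCCCCCC/C=C\CCCCCCC(=O)c1ccccn1` carries a (pyridin-2-yl)carbonyl at the end of its long unsaturated chain. In an assay on isolated protein for inhibition of Fatty-acid amide hydrolase 1 (Homo sapiens) (a higher number here means a weaker inhibitor, a lower number a stronger inhibitor), compound 1 reaches only the limit of the assay, > 100000 nM. Compound 2 `CCCCCCCC/C=C\CCCCCCC(=O)c1nc(-c2ccccc2)c(-c2ccccc2)o1` likewise stops at the limit in this assay, > 100000 nM. Compound 3 `CCCCCCCC/C=C\CCCCCCC(=O)c1nc2ccc(C)cc2o1` also sits at the limit in this assay, > 100000 nM. Compound 1 therefore stands nowhere distinct, since the limit of > 100000 nM in this assay, at which 3 of the 3 values shown sit, covers every value shown. Compound 4 `CCCCCCCC/C=C\CCCCCCC(=O)c1ncco1` is not yet measured; it differs from compound 1 by 1,3-oxazol-2-yl in place of pyridin-2-yl on a carbonyl carbon. Among the compounds with values here, no measured pair maps this change, and with all three values at the limit the account expects for compound 4 no step beyond the scatter in this assay. The expected step is a number no higher from compound 1 to compound 4 (the limit leaves the size open). Compound 4 is estimated at 100000 nM, with a range from 20000 nM to 300000 nM.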

Compound 4, inhibition constant: 17 nM
Compound 4: the middle estimate sits 5900-fold (3.77 log units) above what was measured, and the stated range ends above it.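

With the chain held constant, the group on the carbonyl carbon proves able to move the reading in this assay: 1,3-oxazol-2-yl in place of pyridin-2-yl gives an at least 5800-fold lower number from compound 1 to compound 4 (3.76 log units; beyond the scatter), a large change beyond the scatter. The earlier compounds shown here gave no sign that this position could respond at all, and compound 4 alone comes off the limit: the limit of > 100000 nM in this assay, at which 3 of the 4 values shown sit.

From the compounds shown here alone, what remains open is how a methyl group or a carboxylic acid on the 1,3-oxazol-2-yl ring would read, and what a shorter saturated chain would do to the number.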